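The source may hold more compounds than are shown below. What is called first, only, known or untested is meant among the compounds shown, and "the series" means these compounds.

Three compounds share one core and differ only in the group on a saturated chain carbon bound to an oxygen on an aromatic ring. Compound 1 `COc1cccc(OC)c1OCCNCCOc1ccccc1OCc1cccc(Cl)c1` gives 8.12 in a functional assay on Vas deferens for antagonist activity at Alpha-1A adrenergic receptor (Rattus norvegicus); on this read-out lower numbers stand for lower potency and higher numbers for higher potency (the scale is a negative logarithm). Compound 2 `COc1cccc(OC)c1OCCNCCOc1ccccc1OCc1ccccc1C` gives 7.81 in this assay, and compound 3 `COc1cccc(OC)c1OCCNCCOc1ccccc1OCc1ccc([N+](=O)[O-])cc1` gives 8.58 in this assay. Compound 2 thus stands lowest of the three: the step of a number 0.31 log units lower from compound 1 to compound 2 (beyond the scatter) runs downward, while the step of a number 0.77 log units higher from compound 2 to compound 3 (beyond the scatter) runs upward and is the larger of the two.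

Compound 4 `COc1ccc(COc2ccccc2OCCNCCOc2c(OC)cccc2OC)cc1` is not yet measured. It differs from compound 2 as follows: 4-methoxyphenyl in place of 2-methylphenyl on a saturated chain carbon bound to an oxygen on an aromatic ring. Both measured steps that leave the 2-methylphenyl group, or arrive at it, point the same way, namely that the alternatives to 2-methylphenyl stand higher in this assay. The 4-methoxyphenyl group is a new substituent, so the size of its step can only be bracketed by these two.

For compound 4 a modest upward step, a number 0.39 log units higher from compound 2 to compound 4 (beyond the scatter), is therefore expected in this assay. Compound 4 is estimated at 8.2, with a range from 7.7 to 8.7.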

Compound 4, negative logarithm of the antagonist equilibrium constant: 8.54
Estimate against measurement, compound 4: 0.34 log units below, within the range that was stated.
By their numbers in this assay, from the lowest: compound 2; then compound 1; then compounds 4 and 3 (each within the scatter of the next).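

The 4-methoxyphenyl group lies clearly above the 2-methylphenyl group, with a number 0.73 log units higher from compound 2 to compound 4 (beyond the scatter) in this assay, and also above the 3-chlorophenyl group, with a number 0.42 log units higher from compound 1 to compound 4 (beyond the scatter) in the same read-out. The earlier compounds had shown a high number only for the 4-nitrophenyl group, but now a number 0.04 log units lower from compound 3 to compound 4 (within the scatter) shows that methoxy can take the place of nitro with no change that can be told from the scatter. Among these four compounds, both groups named with a 4 stand above the other two and no compound goes against this, but nothing at hand says why.

Going by these compounds, it stays open whether the methoxy group would hold its number on another ring carbon, since each substituent appears in one place only. The compounds also leave open how an unsubstituted phenyl group, a 4-aminophenyl group or a 4-carboxyphenyl group would stand here.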